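Anilino series: from compound 2 to compound 3 in cell cytotoxicity

This account rests on a few compounds, and the source may have more. Where it says the series, first, only, none or still open, it means among the compounds named here.

Measured so far:
compound 1 `Fc1cccc(-c2nc(Nc3ccccc3)c3ccccc3n2)c1` — > 50000 nM
compound 2 `Fc1cccc(-c2nc(Nc3ccc(Br)cc3)c3cc(F)ccc3n2)c1` — > 50000 nM

In a functional assay on HL-60 cells (Homo sapiens) for cytotoxicity, read by MTT assay, with a stated time of 48 h (a higher number here means a weaker inhibitor, a lower number a stronger inhibitor), compound 1 gives > 50000 nM, which is a limit of the assay and not a number. In this assay compound 2 gives > 50000 nM, again a limit rather than a number. For the measured compounds named here, compound 2 therefore stands at the limit, and the one further value shown sits there too: the limit of > 50000 nM in this assay, at which 2 of the 2 values shown sit. Going by the values given here, no step between measured compounds can be read, since compounds 1 and 2 differ in more than one place, so the two values show only that neither reaches a measurable half-maximal inhibitory concentration.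

Compound 3 `Cc1cccc(Nc2nc(-c3cccc(F)c3)nc3ccc(F)cc23)c1` is the next member. It differs from compound 2 by 3-methylphenyl in place of 4-bromophenyl on a nitrogen on an aromatic ring. With both shown values at the limit, no step beyond the usual scatter is expected in this assay in either direction; the expected step is a number no higher from compound 2 to compound 3 (the limit leaves the size open), and most likely compound 3 will again return only a limit. On that basis compound 3 is estimated at 50000 nM in this assay, within a range of 20000 nM to 150000 nM.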

Compound 3, half-maximal inhibitory concentration: > 50000 nM
Compound 3 gave a limit, no number; the forecaster's own chance of this, stated with the estimate: 80%; the middle value lies on the limit itself.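

Compound 3 gives > 50000 nM in this assay and that is a limit of the assay, not a number. No step can be read from compound 2 to compound 3, since both stand at the limit: the limit of > 50000 nM in this assay, at which 3 of the 3 values shown sit.

The compounds shown leave open whether 3-methylphenyl and 4-bromophenyl differ at all in this assay and what change to the shared core would bring a measurable half-maximal inhibitory concentration.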